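Does a Ring Methyl Shift Adenosine Receptor Binding?

This account rests on a few compounds, and the source may have more. Where it says the series, first, only, none or still open, it means among the compounds named here.

Four compounds share one core. For compound 1 `CN(C(=O)CCCc1ccccc1)c1nc2ccccc2c(=O)s1` the entry in an assay on CHO cells for displacement of a labelled ligand from adenosine receptor A1 (Homo sapiens), read by scintillation counting, with a stated time of 90 min (a lower number here means a stronger inhibitor, a higher number a weaker inhibitor), is "not determined" (no result reported). Compound 2 `O=C(CCCc1ccccc1)Nc1nc2ccccc2c(=O)s1` and compound 3 `O=C(CCc1ccccc1)Nc1nc2ccccc2c(=O)s1` were tested in this assay. Compound 2 gives 2500 nM, the higher of the two numbers; compound 3 gives 1050 nM, and the change is a 2.4-fold lower number from compound 2 to compound 3 (0.38 log units; beyond the scatter). Compound 4 `Cc1ccc2nc(NC(=O)CCCc3ccccc3)sc(=O)c2c1` differs from compound 2 in one place only.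
methyl in place of hydrogen on an aromatic carbon
Among the compounds with values here, the single measured step altered the chain, not the ring, so it does not speak to this change, and no other measured step does either. A methyl on the ring is therefore expected to move the number little, if at all, beyond the scatter, giving an expected 1.3-fold lower number from compound 2 to compound 4 (0.10 log units; within the scatter). Compound 4 is estimated at 2000 nM, with a range from 800 nM to 5000 nM.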

Compound 4, inhibition constant: 1000 nM
The estimate for compound 4 lay 2.0-fold (0.30 log units) above the measured number; the range from low to high includes it.
By their numbers in this assay, from the lowest: compounds 4 and 3 (each within the scatter of the next); then compound 2.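

In this assay a methyl in place of hydrogen on this aromatic carbon gives a 2.5-fold lower number from compound 2 to compound 4 (0.40 log units; beyond the scatter) for a single added carbon. Within the data shown here, the step is modest but beyond the scatter, and it shows that the ring of the shared core, which no earlier step touched, can also move the number. Nothing at hand explains this shift.

The compounds shown leave open what an ethyl, a methoxy or a chlorine would do at this position. They also leave open whether a methyl on another carbon of this ring, or on the shorter chain of compound 3, would give a similar step.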